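Tetrazolyl for Triazolyl: Expected Cytotoxicity of Compound 4

The source may hold more compounds than are shown below. What is called first, only, known or untested is meant among the compounds shown, and "the series" means these compounds.

Three compounds were tested in an ADME assay on NIH3T3 cells (Mus musculus) for cytotoxicity, read by MTT assay, with a stated time of 24 h; on this read-out higher numbers stand for weaker inhibition and lower numbers for stronger inhibition. Compound 1 `Cn1nnnc1SCC(=O)N/N=c1/scc(-c2ccc(Br)cc2)n1-c1ccccc1` gives 19.3 ug/mL, compound 2 `Cn1cnnc1SCC(=O)N/N=c1/scc(-c2ccc(Br)cc2)n1-c1ccccc1` gives 58.3 ug/mL, and compound 3 `Cn1cnnc1SCC(=O)N/N=c1/scc(-c2ccc(C#N)cc2)n1-c1ccccc1` gives 153 ug/mL. Compound 2 and compound 1 differ by 1-methyl-1H-tetrazol-5-yl in place of 4-methyl-4H-1,2,4-triazol-3-yl on a sulfur. That change gave a 3.0-fold lower number from compound 2 to compound 1 (0.48 log units; beyond the scatter). Compound 2 and compound 3 differ by cyano in place of bromo on an aromatic carbon. That change gave a 2.6-fold higher number from compound 2 to compound 3 (0.42 log units; beyond the scatter). Compound 4 `Cn1nnnc1SCC(=O)N/N=c1/scc(-c2ccc(C#N)cc2)n1-c1ccccc1` has not yet been measured. For the measured compounds named here, it differs from compound 3 by 1-methyl-1H-tetrazol-5-yl in place of 4-methyl-4H-1,2,4-triazol-3-yl on a sulfur, the same change, at the same place, as the one made from compound 2 to compound 1. The expectation for compound 4 rests on compound 3 with 153 ug/mL and on the earlier step of a 3.0-fold lower number from compound 2 to compound 1 (0.48 log units; beyond the scatter). Compound 4 is accordingly expected to make a step of a 3.0-fold lower number from compound 3 to compound 4 (0.48 log units; beyond the scatter) in this assay. Compound 4 is estimated at 51 ug/mL, expected to fall between 25 ug/mL and 105 ug/mL.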

Compound 4, half-maximal inhibitory concentration: 213 ug/mL
Compound 4: the middle estimate sits 4.2-fold (0.62 log units) below what was measured; measured number above the stated range.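

In this assay the change to 1-methyl-1H-tetrazol-5-yl gave a 1.4-fold higher number from compound 3 to compound 4 (0.14 log units; within the scatter), so the earlier step did not carry over from the bromo pair to the cyano pair: the same change on two cores in this assay, a 3.0-fold lower number (0.48 log units; beyond the scatter) from compound 2 to compound 1 and a 1.4-fold higher number (0.14 log units; within the scatter) from compound 3 to compound 4, 4.2-fold (0.62 log units) apart, beyond the scatter of two such steps

Read the other way, cyano in place of bromo gave an 11-fold higher number from compound 1 to compound 4 (1.04 log units; beyond the scatter), a larger step than on the triazolyl pair: the same change on two cores in this assay, a 2.6-fold higher number (0.42 log units; beyond the scatter) from compound 2 to compound 3 and an 11-fold higher number (1.04 log units; beyond the scatter) from compound 1 to compound 4, 4.2-fold (0.62 log units) apart, beyond the scatter of two such steps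

For the compounds shown here, both comparisons rest on the same four compounds, so together they show only that the two changes do not act independently here; they do not show why, or how either change would behave on another core.

The compounds shown leave open how the tetrazolyl change behaves with chloro or methoxy on that aromatic carbon. They also leave open the effect of a longer chain on the sulfur.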